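Swapping the Chlorophenyl Arm for an Amino Group

The source may report more compounds than this note shows. Statements on the series, on what has been measured and on what is new or still open speak of the compounds shown alone.

Measured so far in a functional assay on Jurkat cells (Homo sapiens) for antiproliferative activity, read by WST assay, with a stated time of 72 h; on this read-out higher numbers stand for weaker inhibition and lower numbers for stronger inhibition:
- Compound 1, `Cc1noc(-c2cc3ccccc3[nH]2)n1`: in this assay compound 1 returns only a limit, > 50000 nM.
- Compound 2, `c1ccc(-c2noc(-c3cc4ccccc4[nH]3)n2)cc1`: in this assay compound 2 likewise returns only a limit, > 50000 nM.
- Compound 3, `Clc1ccc(-c2noc(-c3cc4ccccc4[nH]3)n2)cc1`: in this assay compound 3 also returns only a limit, > 50000 nM.

All three compounds share the same core and carry a different group on one aromatic carbon of the five-membered ring. None of them produced a number; each sits at the ceiling of the assay, as the limit of > 50000 nM in this assay, at which 3 of the 3 values shown sit, records. Because of the limit of > 50000 nM in this assay, at which 3 of the 3 values shown sit, the steps between them cannot be sized: a step that the two limits leave unreadable from compound 1 to compound 2, a step that the two limits leave unreadable from compound 1 to compound 3 and a step that the two limits leave unreadable from compound 2 to compound 3 are all unreadable. Compound 3 therefore stands only as a limit, with no readable distance to compound 1 or compound 2.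

The next compound, compound 4, is `Nc1noc(-c2cc3ccccc3[nH]2)n1`. It differs from compound 3 in one place: amino in place of 4-chlorophenyl on an aromatic carbon.

Going by the values given here, no measured step gives guidance for this change, since every step so far was unreadable. The most defensible expectation is that compound 4 again lands at or near the ceiling; compound 4 is estimated at about 50000 nM, with a range from 10000 nM to 200000 nM. That expectation amounts to an estimated step of a number no higher from compound 3 to compound 4 (the limit leaves the size open), which cannot be checked against any readable step from the measured compounds.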

Compound 4, half-maximal inhibitory concentration: > 50000 nM
Compound 4 was reported as a limit (the forecaster's own chance of this, stated with the estimate: 75%); the middle value sits exactly at the limit.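

The steps from compound 1, compound 2 and compound 3 to compound 4 cannot be read, because all four compounds stop at the same limit: the limit of > 50000 nM in this assay, at which 4 of the 4 values shown sit.

The compounds shown leave open whether methyl, phenyl, 4-chlorophenyl and amino differ at all in their effect in this assay, since none of the four gives an actual number.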